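The source may hold more compounds than are shown below. What is called first, only, known or untested is meant among the compounds shown, and "the series" means these compounds.

Working notes on the series. Three compounds have numbers in a functional assay on HL-60 cells (Homo sapiens) for cytotoxicity, read by WST assay, with a stated time of 48 h; a lower number here means a stronger inhibitor, a higher number a weaker inhibitor. Compound 1 `COc1ccc(/C=C/C[C@H]2C[C@H]([C@H](O)c3ccc(OC)c(OC)c3)CO[C@@H]2c2ccc(OC)c(OC)c2)cc1OC` gives 23500 nM, compound 2 `O[C@@H](c1ccccc1)[C@H]1CO[C@H](c2ccccc2)[C@@H](C/C=C/c2ccccc2)C1` gives 7040 nM, and compound 3 `CCCCCC/C=C/C[C@H]1C[C@@H]([C@@H](O)c2ccccc2)CO[C@@H]1c1ccccc1` gives 4990 nM. Compound 3 carries the lowest of the three numbers; its nearest neighbour is compound 2, while compound 1 sits furthest from it. Among the compounds with values here, the one single-point step recorded is a 1.4-fold lower number from compound 2 to compound 3 (0.15 log units; within the scatter).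

Compound 4 `Oc1ccccc1/C=C/C[C@H]1C[C@@H]([C@@H](O)c2ccccc2)CO[C@@H]1c1ccccc1` is the next compound, differing from compound 3 only as follows: 2-hydroxyphenyl in place of hexyl on a double-bonded chain carbon bound to a double-bonded chain carbon. Within the data shown here, the step from compound 2 to compound 3 is the only one bearing on this change, and it was small. A step of similar size is therefore expected back toward the value of compound 2, estimated as a 1.4-fold higher number from compound 3 to compound 4 (0.15 log units; within the scatter), not beyond the scatter. Compound 4 is expected to give 7000 nM, with a range from 2500 nM to 20000 nM.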

Compound 4, half-maximal inhibitory concentration: 10800 nM
For compound 4 the middle estimate is 1.5-fold (0.19 log units) below the measured one, within the range that was stated.
By their numbers in this assay, from the lowest: compounds 3, 2 and 4 (each within the scatter of the next, the first and the last beyond it); then compound 1.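

In this assay, the place on the double-bonded chain carbon now shows a change beyond the scatter, though a modest one: 2-hydroxyphenyl in place of hexyl gives a 2.2-fold higher number from compound 3 to compound 4 (0.34 log units; beyond the scatter) on the shared core. Hydroxy in place of hydrogen on an aromatic carbon gives a 1.5-fold higher number from compound 2 to compound 4 (0.19 log units; within the scatter), so that single change stays within the scatter. Nothing measured here accounts for the step away from hexyl.

On these data alone, whether a longer chain than hexyl at this place, or an amine in place of the hydroxy, would shift the number remains open.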